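One Chlorine More on the Shared Core

The source may hold more compounds than are shown below. What is called first, only, known or untested is meant among the compounds shown, and "the series" means these compounds.

Measured compounds:
compound 1, `Nc1nc(Cl)c2ncn(Cc3ccc(CCl)cc3)c2n1`: 15100 nM
compound 2, `ClCc1ccc(Cn2cnc3ncnc(Cl)c32)cc1`: 11200 nM

Both values come from a functional assay on SK-OV-3 cells (Homo sapiens) for cytotoxicity, read by sulforhodamine B assay, with a stated time of 48 h; a higher number here means a weaker inhibitor of growth, a lower number a stronger inhibitor of growth. On these numbers compound 2 stands lowest of the two, but compound 1 lies only a short distance above it and within the scatter, so no order between the two can be claimed from them. Compound 3, `ClCc1ccc(Cn2cnc3nc(Cl)nc(Cl)c32)cc1`, has not yet been measured. It differs from compound 2 by chloro in place of hydrogen on an aromatic carbon. Going by the values given here, no step between measured compounds carries this change, so the expectation rests on the two numbers alone. Compound 1 bears a different substituent in that place, and its value sits within the scatter of compound 2, which suggests that the carbon in question tolerates change without a large shift in the read-out. The step of a 1.2-fold lower number from compound 2 to compound 3 (0.09 log units; within the scatter) is therefore expected to be small, at most a modest move toward stronger growth inhibition and possibly none beyond the scatter. Compound 3 is estimated at 9000 nM, with a plausible range from 3000 nM to 25000 nM.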

Compound 3, concentration for 50% growth inhibition: 2340 nM
The estimate for compound 3 lay 3.8-fold (0.59 log units) above the measured number; measured number below the stated range.
By their numbers in this assay, from the lowest: compound 3; then compounds 2 and 1 (each within the scatter of the next).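

In this assay, the aromatic carbon between two ring nitrogen atoms turns out to respond to substitution: chloro in place of hydrogen gives a step beyond the scatter (a 4.8-fold lower number from compound 2 to compound 3 (0.68 log units; beyond the scatter)). The earlier pair could not show this, since compound 1 and compound 2 lie within the scatter of each other, and the new value shows that the outcome at this carbon depends on which group stands there: compound 1, with an amine at this carbon, gives (15100 nM), whereas compound 3, with chloro, gives (2340 nM). Nothing measured in this set accounts for the step.

The compounds shown leave open whether other groups on this carbon, such as fluoro, methoxy or a nitrile, would stay close to hydrogen and the amine or would move the number as chloro does. They also leave open whether the step would persist if the chloro group meta to this carbon were replaced by an amine or a methoxy group, so the change is known on this one shared core only.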